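Methyl added to compound 2, configuration opposite to compound 1

This account rests on a few compounds, and the source may have more. Where it says the series, first, only, none or still open, it means among the compounds named here.

In a functional assay on SW480 cells (Homo sapiens) for cytotoxicity, read by MTT assay, with a stated time of 72 h (a lower number here means a stronger inhibitor, a higher number a weaker inhibitor), compound 2 (`O=c1c2ccccc2sn1Cc1ccccc1`) gives 23800 nM and lies within the scatter of compound 1 (`C[C@@H](c1ccccc1)n1sc2ccccc2c1=O`) at 41800 nM on this read-out. Compound 3 (`C[C@H](c1ccccc1)n1sc2ccccc2c1=O`) is unmeasured. It differs from compound 2 by methyl in place of hydrogen on a saturated chain carbon bound to an aromatic carbon and an aromatic nitrogen and carries that methyl in the configuration opposite to compound 1. For the measured compounds named here, the one step bearing on it is a 1.8-fold lower number from compound 1 to compound 2 (0.24 log units; within the scatter) at the same place. Going by the values given here, no measured pair yet compares the two configurations, so nothing beyond the scatter is expected in this assay. The expected step is a 1.5-fold higher number from compound 2 to compound 3 (0.17 log units; within the scatter) by this estimate. Compound 3 is estimated at 35000 nM with an expected range from 16000 nM to 75000 nM for now.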

Compound 3, half-maximal inhibitory concentration: 43100 nM
Beside the measured number, compound 3's estimate is 1.2-fold (0.09 log units) below it; the range from low to high includes it.
By their numbers in this assay, from the lowest: compounds 2, 1 and 3 (each within the scatter of the next).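

The two configurations at the saturated chain carbon can now be compared directly: in this assay the comparison gives a 1.0-fold higher number from compound 1 to compound 3 (0.01 log units; within the scatter) and shows no separation beyond the scatter. Methyl in place of hydrogen at this carbon gives a 1.8-fold higher number from compound 2 to compound 3 (0.26 log units; within the scatter) and so stays within the scatter in this configuration too. The comparison isolates configuration alone: the fact that compounds 1 and 3 differ only in the configuration as drawn. Open, going by these compounds, is whether a longer chain, an amine or a carboxylic acid in place of the methyl on this carbon would move the number beyond the scatter.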